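Amide Variations on a Shared Thyrotropin Receptor Core

A few compounds are considered here, and "the series" means these few. Any claim that something is new, unique, unknown or untested is made for them only; others in the source may bear on it.

Compound 1 `COc1cccc(-c2nc(SC)nc3sc(C(=O)NCc4ccccc4)c(N)c23)c1`: 3%
Compound 2 `COc1cccc(-c2nc(SC)nc3sc(C(=O)N(C)C(C)(C)C)c(N)c23)c1`: 3.6%
Compound 3 `COc1cccc(-c2nc(SC)nc3sc(C(=O)NCC#N)c(N)c23)c1`: 3.6%

Three compounds share one core and differ only in the group attached to the carbonyl carbon of the amide. In a functional assay on HEK293 cells for agonist activity at Thyrotropin receptor (Homo sapiens), read by cAMP accumulation (a lower number here means a smaller maximal response, a higher number a larger maximal response), compound 1 gives 3%, compound 2 gives 3.6%, and compound 3 gives 3.6%. Compound 3 matches compound 2 exactly, and the step of a number 0.6 percentage points higher from compound 1 to compound 3 (within the scatter), like a number 0.6 percentage points higher from compound 1 to compound 2 (within the scatter) and no change at the digits printed from compound 2 to compound 3 (within the scatter), lies within the scatter. All three values are small, so each compound produces only a weak maximal response.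

Compound 4 `COc1cccc(-c2nc(SC)nc3sc(C(=O)NN)c(N)c23)c1` has not yet been measured. Relative to compound 3 the change is amino in place of cyanomethyl on an amide-type nitrogen. The three measured steps all alter the group on this amide, and none moved the read-out beyond the scatter, so the same outcome is expected here: a step of a number 0.1 percentage points lower from compound 3 to compound 4 (within the scatter) in this assay is expected, meaning no change beyond the scatter in either direction. Compound 4 is therefore expected to give 3.5%, within a range from 0% to 10%.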

Compound 4, largest response reached (reported as efficacy), in percent of the reference or control that the assay uses: 6.1%
Compound 4: the middle estimate sits 2.6 percentage points below what was measured; measured number inside the range.
By their numbers in this assay, from the lowest: compounds 1, 2, 3 and 4 (each within the scatter of the next).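

In this assay the amino group gives a number 2.5 percentage points higher from compound 3 to compound 4 (within the scatter) and a number 2.5 percentage points higher from compound 2 to compound 4 (within the scatter) and also a number 3.1 percentage points higher from compound 1 to compound 4 (within the scatter) on this amide-type nitrogen. The group here can therefore shrink to amino, a single heavy atom, and compound 4 still cannot be separated from the other three compounds, whose amide groups range from benzylamino to methyl(tert-butyl)amino. No supporting measurement is available that would explain these numbers.

The compounds shown leave open whether any group on this nitrogen can lift the response beyond the scatter, for example a longer chain ending in a primary amine or a carboxylic acid. From the compounds shown here alone, what a change elsewhere on the shared core would do also stays open.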